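The compounds below may be only part of what the source reports. "The series", "measured", "known", "first", "only" and "open" are said of these compounds alone.

Measured so far:
- compound 1 `CCc1nn(CC)c(C2CCN(C(=O)CN3CN(c4ccccc4)C4(CCN(C(=O)c5ccc(C6CCCCC6)cc5)CC4)C3=O)CC2)c1C`: "not determined" (no result reported)
- compound 2 `CCOC(=O)C1CCN(C(=O)CN2CN(c3ccccc3)C3(CCN(C(=O)c4ccc(C5CCCCC5)cc4)CC3)C2=O)CC1`: 900 nM
- compound 3 `CC(C)(C)c1ccc(C(=O)N2CCC3(CC2)C(=O)N(CC(=O)N2CCN(S(C)(=O)=O)CC2)CN3c2ccccc2)cc1`: 19000 nM

All numbers come from an assay on HEK293 cells for displacement of a labelled ligand from NPC1-like intracellular cholesterol transporter 1 (Homo sapiens); on this read-out higher numbers stand for weaker inhibition and lower numbers for stronger inhibition. Compound 3 holds the highest of the two numbers; compound 2 sits at a lower number, with the gap beyond the scatter, and compound 1 contributes no number. Compound 4 `CC(C)(C)c1ccc(C(=O)N2CCC3(CC2)C(=O)N(CC(=O)N2CCCC(CO)C2)CN3c2ccccc2)cc1` keeps everything of compound 3 except one change: 3-(hydroxymethyl)piperidin-1-yl in place of 4-(methylsulfonyl)piperazin-1-yl on a carbonyl carbon. Among the compounds with values here, no step between measured compounds covers this change, and compound 2 differs from compound 3 in more than one place, so only its value can be set beside it. In this assay compound 4 is expected at a lower number than compound 3, by a step of a 2.4-fold lower number from compound 3 to compound 4 (0.38 log units; beyond the scatter) that may only just exceed the scatter. The estimate for compound 4 is 8000 nM, within 2500 nM to 25000 nM.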

Compound 4, half-maximal inhibitory concentration: 8200 nM
Compound 4: the middle estimate sits 1.0-fold (0.01 log units) below what was measured; low and high end bracket the measured number.
By their numbers in this assay, from the lowest: compound 2; then compound 4; then compound 3.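

In this assay, the group on this carbonyl carbon now has a single-place reading: 3-(hydroxymethyl)piperidin-1-yl in place of 4-(methylsulfonyl)piperazin-1-yl gives a 2.3-fold lower number from compound 3 to compound 4 (0.36 log units; beyond the scatter), a modest step. The 4-(methylsulfonyl)piperazin-1-yl group is therefore not required for the inhibition seen in this series. Nothing available explains the size or direction of this step.

Within the data shown here, the single step changes the ring and its substituent together, so their contributions remain unseparated. Plain piperidine, 4-(hydroxymethyl)piperidine and a piperidine carrying a carboxylic acid would each help to separate them.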